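The source may hold more compounds than are shown below. What is called first, only, known or untested is meant among the compounds shown, and "the series" means these compounds.

Measured compounds:
compound 1 `CC(C)(C)N(NC(=O)c1ccccc1)C(=O)c1ccccc1Cl`, 75.9 nM
compound 2 `Cc1cc(C)cc(C(=O)N(NC(=O)c2ccccc2)C(C)(C)C)c1`, 69.2 nM
compound 3 `Cc1cc(C)c(Cl)c(C(=O)N(NC(=O)c2ccccc2)C(C)(C)C)c1`, 1170 nM

In an assay on cells for agonist activity at ecdysone receptor (Bombyx mori), read by a luciferase reporter, with a stated time of 24 h (on this read-out higher numbers stand for an effect only at larger amounts of compound and lower numbers for an effect already at smaller amounts), compound 2 gives the lowest number of the three, though compound 1 lies within the scatter of it a 1.1-fold lower number from compound 1 to compound 2 (0.04 log units; within the scatter), while compound 3 lies far beyond it a 17-fold higher number from compound 2 to compound 3 (1.23 log units; beyond the scatter). Compound 4 `CCCCCCCC(=O)NN(C(=O)c1cc(C)cc(C)c1)C(C)(C)C` differs from compound 2 by heptyl in place of phenyl on a carbonyl carbon. Neither measured step touches this part of the shared core: the step from compound 1 to compound 2 swaps one aromatic group for another, and the step from compound 2 to compound 3 adds a chloro on an aromatic carbon. No measured change removes an aromatic ring entirely, so the expectation rests on the size of the change alone. Trading phenyl for heptyl is a large change, and a step beyond the scatter toward higher numbers is expected, a 29-fold higher number from compound 2 to compound 4 (1.46 log units; beyond the scatter). Compound 4 is therefore estimated at 2000 nM, with a wide range from 200 nM to 20000 nM.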

Compound 4, half-maximal effective concentration: 97.7 nM
Estimate against measurement, compound 4: 20-fold (1.31 log units) above; measured number outside the range, below it.
By their numbers in this assay, from the lowest: compounds 2, 1 and 4 (each within the scatter of the next); then compound 3.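

In this assay, heptyl in place of phenyl on the carbonyl carbon gives a 1.4-fold higher number from compound 2 to compound 4 (0.15 log units; within the scatter) and so stays within the scatter. This is the first step shown at this position, and it shows that, between these two compounds, an open chain with no ring can stand where the aromatic ring stood without a change that can be told from the scatter. Nothing available gives a reason for this result.

As far as these compounds go, whether a shorter chain, a longer chain or a chain ending in an amine or a carboxylic acid would fit this position equally well remains open. Also open, from the compounds shown here alone, is whether a chloro on the aromatic carbon, as in compound 3, would have a similar effect alongside heptyl.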